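From Cyano to Ethynyl: Expected Cytotoxicity of Compound 4

This account rests on a few compounds, and the source may have more. Where it says the series, first, only, none or still open, it means among the compounds named here.

Compound 1 `Cc1ccc(S(=O)(=O)N[C@@H](CC(=O)NC(C)(C)C)C(=O)NCCNC(=O)c2ccc(F)c(F)c2)cc1`: in an ADME assay on Karpas-1106P cells (Homo sapiens) for cytotoxicity (a lower number here means that less compound is needed, a higher number that more compound is needed for the effect), compound 1 gives > 11100 nM, which is a limit of the assay.
Compound 2 `Cc1ccc(S(=O)(=O)N[C@@H](CC(=O)NC(C)(C)C)C(=O)NCCNC(=O)c2ccccc2O)cc1`: in this assay compound 2 gives > 11100 nM, also a limit.
Compound 3 `Cc1ccc(S(=O)(=O)N[C@@H](CC(=O)NC(C)(C)C)C(=O)NCCNC(=O)c2cccc(C#N)c2)cc1`: in this assay compound 3 gives > 11100 nM, again a limit.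

Compound 3 therefore stands at the limit of > 11100 nM in this assay, at which 3 of the 3 values shown sit, where every measured value sits. Compound 4 `C#Cc1cccc(C(=O)NCCNC(=O)[C@H](CC(=O)NC(C)(C)C)NS(=O)(=O)c2ccc(C)cc2)c1` differs from it by ethynyl in place of cyano on an aromatic carbon. Going by the values given here, the steps that bear on this change, a step that the two limits leave unreadable from compound 1 to compound 3 and a step that the two limits leave unreadable from compound 2 to compound 3, cannot be read in size or direction; each end is a limit. No step beyond the scatter can be expected in this assay, in either direction. Compound 4 is expected to remain at the limit, estimated at 15000 nM with a range from 7000 nM to 40000 nM. The expected step is a step that the limit leaves unreadable from compound 3 to compound 4.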

Compound 4, half-maximal effective concentration: > 11100 nM
Compound 4: a limit, no number; the forecaster's own chance of this, stated with the estimate: 80%; the middle value does not contradict the limit.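

Compound 4 gives a limit, not a number, so its steps from compound 1, compound 2 and compound 3 cannot be read in this assay: the limit of > 11100 nM in this assay, at which 4 of the 4 values shown sit.

The compounds shown leave open whether these four differ at all in cytotoxicity, and which group on the carbonyl carbon would give a readable number.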